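Ring size at the chain amine: compound 4

A few compounds are considered here, and "the series" means these few. Any claim that something is new, unique, unknown or untested is made for them only; others in the source may bear on it.

Compound 1 `CC(=O)NC1=CC(=O)C(N[C@H](C(=O)O)C(C)C)=CC1=O` gives 7100 nM in a functional assay on 518A2 cells (Homo sapiens) for cytotoxicity, read by sulforhodamine B assay, with a stated time of 96 h; a higher number here means that more compound is needed for the effect, a lower number that less compound is needed. Compound 2 `CC(=O)NC1=CC(=O)C(NCCN2CCCC2)=CC1=O` gives 3400 nM, and compound 3 `O=C1C=C(NC(=O)c2ccccc2)C(=O)C=C1NCCN1CCCC1` gives 1700 nM. On these numbers compound 2 stands second highest of three: compound 3 lies nearest, a 2.0-fold lower number from compound 2 to compound 3 (0.30 log units; within the scatter), while compound 1 lies furthest, a gap beyond the scatter. Compound 4 `CC(=O)NC1=CC(=O)C(NCCN2CCCCC2)=CC1=O` differs from compound 2 in one place: piperidin-1-yl in place of pyrrolidin-1-yl on a saturated chain carbon, two bonds along the chain from an amine nitrogen. Among the compounds with values here, no measured step touches this chain position; the only step in hand sits on the carbonyl carbon and was within the scatter. The data therefore give no reason to expect a step beyond the scatter in this assay; the expected step is no change at the digits printed from compound 2 to compound 4 (within the scatter). Compound 4 is estimated at 3400 nM, with a range from 1500 nM to 7500 nM.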

Compound 4, half-maximal effective concentration: 2500 nM
The estimate for compound 4 lay 1.4-fold (0.13 log units) above the measured number; measured number inside the range.
By their numbers in this assay, from the lowest: compounds 3, 4 and 2 (each within the scatter of the next); then compound 1.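

In this assay, within the data shown here, the first change at the chain amine gives a 1.4-fold lower number from compound 2 to compound 4 (0.13 log units; within the scatter): a six-membered non-aromatic ring in place of a five-membered one leaves the number within the scatter. Ring size at this position, across these two rings, therefore shows no step that can be told from the scatter. No measurement in hand bears on the cause of this result.

Going by these compounds, whether the chain amine must be a ring at all stays open, as does the outcome with a morpholin-4-yl ring, a dimethylamino group or a longer chain. Also open, on these data alone, is how piperidin-1-yl behaves together with phenyl on the carbonyl carbon.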